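From Phenethyl to 1-Phenoxypropyl on a Carbonyl Carbon

This account rests on a few compounds, and the source may have more. Where it says the series, first, only, none or still open, it means among the compounds named here.

In a functional assay for inhibition, with Rattus norvegicus as the target, at pH 7.35 (on this read-out higher numbers stand for weaker inhibition and lower numbers for stronger inhibition), compound 1 (`CCOC(=O)C(=O)C(CC)NC(=O)C(CC(C)C)NC(=O)OCc1ccccc1`) gives 300000 nM and compound 2 (`CCOC(=O)C(=O)C(CC)NC(=O)C(CC(C)C)NC(=O)CCc1ccccc1`) gives 20000 nM as the lower of the two numbers. Compound 3 (`CCOC(=O)C(=O)C(CC)NC(=O)C(CC(C)C)NC(=O)C(CC)Oc1ccccc1`) carries 1-phenoxypropyl in place of phenethyl on a carbonyl carbon, and 1-phenoxypropyl in place of phenethyl on a carbonyl carbon gives the count of that change. For the measured compounds named here, the only measured step, a 15-fold lower number from compound 1 to compound 2 (1.18 log units; beyond the scatter), is large and also changes the group on a carbonyl carbon. It is a single precedent with a different group, so a smaller move to a lower number is expected, and the estimated step is a 2.5-fold lower number from compound 2 to compound 3 (0.40 log units; beyond the scatter) in this assay as a rough guide. Compound 3 is expected at 8000 nM on a range from 1500 nM to 40000 nM in this estimate.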

Compound 3, half-maximal inhibitory concentration: 22000 nM
Compound 3: middle estimate off by 2.8-fold (0.44 log units), on the low side, and the stated range covers the measured number.
By their numbers in this assay, from the lowest: compounds 2 and 3 (each within the scatter of the next); then compound 1.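

In this assay, 1-phenoxypropyl in place of phenethyl on this carbonyl carbon gives a 1.1-fold higher number from compound 2 to compound 3 (0.04 log units; within the scatter), so the larger group, with its added oxygen and hydrogen-bond acceptor, leaves the number within the scatter. Set against benzyloxy, the same group gives a 14-fold lower number from compound 1 to compound 3 (1.13 log units; beyond the scatter), which shows that phenethyl is not the only group separated from benzyloxy by a large step at this place. Nothing available gives a reason for either step. From the compounds shown here alone, what remains open is whether a longer chain or an amine on this carbonyl carbon would move the number beyond the scatter from that of compound 2.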